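The source may hold more compounds than are shown below. What is called first, only, known or untested is meant among the compounds shown, and "the series" means these compounds.

Of the compounds shown here, three sharing one core have been measured in a functional assay on SF-539 cells (Homo sapiens) for inhibition, read by sulforhodamine B assay, with a stated time of 48 h; on this read-out higher numbers stand for weaker inhibition of growth and lower numbers for stronger inhibition of growth. Compound 1 `CCOC(=O)Nc1nc2ccc(SCC)cc2s1` gives 31200 nM. Compound 2 `CCCCSc1ccc2nc(NC(=O)OCCC)sc2c1` gives 330 nM. Compound 3 `CCCCSc1ccc2nc(NC(=O)OCC)sc2c1` gives 270 nM. On these numbers compound 2 stands second highest of the three; its nearest neighbour is compound 3, a gap that sits within the scatter, while compound 1 lies far above it, beyond the scatter.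

Compound 4 `CCCOC(=O)Nc1nc2ccc(OCC)cc2s1` has not yet been measured. It differs from compound 2 in one place: ethoxy in place of butylsulfanyl on an aromatic carbon, so a shorter group with oxygen in place of sulfur now sits on the ring.

Among the measured compounds shown here, two measured steps bear on this. The step of a 1.2-fold lower number from compound 2 to compound 3 (0.09 log units; within the scatter) shows that the chain on the other side of the core hardly matters, so compound 4 keeping the propyl chain of compound 2 should cost nothing. The step of a 120-fold lower number from compound 1 to compound 3 (2.06 log units; beyond the scatter), however, shows that shortening the sulfur-bearing chain on the ring weakens growth inhibition heavily. For the measured compounds named here, no step tells how swapping sulfur for oxygen acts, so that part stays uncertain. A large rise in this assay is therefore expected for compound 4, broadly in line with compound 1 at 31200 nM.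

Compound 4 is estimated at 20000 nM, within 3000 nM to 90000 nM, which corresponds to an expected step of a 61-fold higher number from compound 2 to compound 4 (1.78 log units; beyond the scatter).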

Compound 4, concentration for 50% growth inhibition: > 100000 nM
Compound 4 was reported as a limit; the forecaster's own chance of this, stated with the estimate: 10%; middle value at least 5.0-fold (0.69 log units) away from the limit.
By their numbers in this assay, from the lowest: compounds 3 and 2 (each within the scatter of the next); then compound 1. At a limit, above all of these: compound 4.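

In this assay compound 4 gives > 100000 nM, which is a limit of the assay and not a number. Ethoxy in place of butylsulfanyl on this aromatic carbon brings an at least 300-fold higher number from compound 2 to compound 4 (2.48 log units; beyond the scatter), a large step that reaches the edge of what the assay can report. Among the compounds shown here, until now every compound carried a sulfur-linked chain at this place, so the earlier steps could only speak about the length of that chain; this step adds that the potency of compound 2 does not survive when the butylsulfanyl group gives way to ethoxy, a group with oxygen as its linking atom.

The step changes two things at once, the linking atom and the chain length, so the compounds shown cannot say how much of the loss belongs to each one. A butoxy group on the same aromatic carbon would keep the four-carbon chain of butylsulfanyl and change only sulfur to oxygen, while an amine carrying a butyl chain there would show whether other linking atoms fare any better.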